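The source may hold more compounds than are shown below. What is called first, only, known or untested is meant among the compounds shown, and "the series" means these compounds.

Of the compounds shown here, three of one shared core have been measured. Compound 1 `CCC(=O)N1C[C@@H](O[C@H](C)c2cc(C(F)(F)F)cc(C(F)(F)F)c2)[C@H](c2ccc(F)cc2)C1` gives 0.09 nM in an assay on CHO cells for displacement of a labelled ligand from Substance-P receptor (Homo sapiens); on this read-out higher numbers stand for weaker inhibition and lower numbers for stronger inhibition. Compound 2 `C[C@@H](O[C@@H]1CN(C(=O)[C@@H]2CCC(=O)N2C)C[C@H]1c1ccc(F)cc1)c1cc(C(F)(F)F)cc(C(F)(F)F)c1` gives 0.12 nM in this assay, and compound 3 `C[C@@H](O[C@@H]1CN(C(=O)[C@@H]2COC(=O)N2)C[C@H]1c1ccc(F)cc1)c1cc(C(F)(F)F)cc(C(F)(F)F)c1` gives 0.34 nM. Compound 3 therefore stands at the highest number of the three: the step of a 3.8-fold higher number from compound 1 to compound 3 (0.58 log units; beyond the scatter) and the step of a 2.8-fold higher number from compound 2 to compound 3 (0.45 log units; beyond the scatter) both lie beyond the scatter, while the step of a 1.3-fold higher number from compound 1 to compound 2 (0.12 log units; within the scatter) does not.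

Compound 4 `CCNC(=O)N1C[C@@H](O[C@H](C)c2cc(C(F)(F)F)cc(C(F)(F)F)c2)[C@H](c2ccc(F)cc2)C1` is not yet measured. It differs from compound 3 by ethylamino in place of 2-oxo-1,3-oxazolidin-4-yl on a carbonyl carbon. The step that bears on it most directly is a 3.8-fold higher number from compound 1 to compound 3 (0.58 log units; beyond the scatter), since it undoes the same group and puts a short chain back on the carbonyl carbon, with a nitrogen now between the carbonyl and the ethyl. The ethyl of compound 1 and the methylated ring of compound 2 sit close together, so a small amine-bearing chain is expected to land near them rather than near compound 3. The step of a 2.3-fold lower number from compound 3 to compound 4 (0.36 log units; beyond the scatter) is therefore expected to lower the number. Compound 4 is estimated at 0.15 nM, within a range from 0.05 nM to 0.5 nM.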

Compound 4, half-maximal inhibitory concentration: 0.1 nM
Compound 4: the middle estimate sits 1.5-fold (0.18 log units) above what was measured, within the range that was stated.
By their numbers in this assay, from the lowest: compounds 1, 4 and 2 (each within the scatter of the next); then compound 3.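

In this assay, ethylamino on this carbonyl carbon recovers what 2-oxo-1,3-oxazolidin-4-yl loses, with a 3.4-fold lower number from compound 3 to compound 4 (0.53 log units; beyond the scatter). The new group also cannot be told apart from the two other groups at this place, since a 1.1-fold higher number from compound 1 to compound 4 (0.05 log units; within the scatter) and a 1.2-fold lower number from compound 2 to compound 4 (0.08 log units; within the scatter) both lie within the scatter, so a nitrogen-linked chain, a plain ethyl and 1-methyl-5-oxopyrrolidin-2-yl all read alike, and compound 3 alone stands apart from them. No measurement shown gives a reason for this difference.

The compounds shown leave open whether a longer chain such as butylamino, or a carboxylic acid on the same carbonyl carbon, would stay level with compound 4. They also leave open whether replacing the amide hydrogen of ethylamino with a methyl group would change the number.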